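Swapping the Aryl Group on a Shared Urea Core

A few compounds are considered here, and "the series" means these few. Any claim that something is new, unique, unknown or untested is made for them only; others in the source may bear on it.

Of the compounds shown here, three sharing one core have been tested in a functional assay on NCI-H226 cells (Homo sapiens) for inhibition, read by MTT assay, with a stated time of 48 h, tested at 10 uM; on this read-out lower numbers stand for less inhibition and higher numbers for more inhibition at the one concentration tested (going by the name of the read-out). Compound 1 `COc1cc(Nc2cc(NC(=O)Nc3c(Cl)cccc3Cl)ncn2)cc(OC)c1` gives 60%. Compound 2 `COc1cc(NC(=O)Nc2cc(Nc3cc(C)cc(F)c3)ncn2)cc(OC)c1` gives 35.3%, and compound 3 `COc1cc(NC(=O)Nc2cc(Nc3ccc(OC)c(I)c3)ncn2)cc(OC)c1` gives 40.1%. On these numbers compound 3 stands second highest of three: the step of a number 4.8 percentage points higher from compound 2 to compound 3 (within the scatter) lies within the scatter, whereas the number of compound 1 sits higher by an amount beyond the scatter.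

Compound 4 `COc1cc(NC(=O)Nc2cc(Nc3cc(F)ccc3OC)ncn2)cc(OC)c1` has not yet been measured. It differs from compound 3 in one place: 5-fluoro-2-methoxyphenyl in place of 3-iodo-4-methoxyphenyl on a nitrogen on an aromatic ring. Among the compounds with values here, the only measured step at this same place is a number 4.8 percentage points higher from compound 2 to compound 3 (within the scatter), which was within the scatter. Within the data shown here, compound 1 differs from compound 3 in more than one place and offers no step for this change. One small step is slim evidence, but it suggests that exchanging one aryl group for another at this position does little in this assay, so a step of a number 0.1 percentage points lower from compound 3 to compound 4 (within the scatter) is expected, within the scatter. Compound 4 is therefore estimated at 40%, with a range from 25% to 55%.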

Compound 4, a percentage reported as inhibition, at one concentration (the size of the read-out at that concentration, not a potency): 37.7%
Estimate against measurement, compound 4: 2.3 percentage points above, and the stated range covers the measured number.
By their numbers in this assay, from the lowest: compounds 2, 4 and 3 (each within the scatter of the next); then compound 1.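

With compound 4 in hand, the same place on the shared core has now carried three different aryl groups in this assay: there is a number 2.4 percentage points lower from compound 3 to compound 4 (within the scatter) and a number 2.4 percentage points higher from compound 2 to compound 4 (within the scatter), and both steps lie within the scatter. Where one small step stood before, all three pairs among compounds 2, 3 and 4 now read alike, so trading 3-iodo-4-methoxyphenyl or 3-fluoro-5-methylphenyl for 5-fluoro-2-methoxyphenyl on this nitrogen brings no change that this read-out can separate. Nothing available here explains why these groups read alike.

These compounds cover only substituted phenyl groups at this place, so they leave open whether the same flat picture would hold for a group without an aromatic ring, such as a morpholine or a simple alkyl chain. A phenyl ring bearing a carboxylic acid or an amine also remains untested in what is shown here.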